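This account rests on a few compounds, and the source may have more. Where it says the series, first, only, none or still open, it means among the compounds named here.

Measured so far in an assay on HEK293 cells for displacement of a labelled ligand from 5-hydroxytryptamine receptor 6 (Homo sapiens), read by scintillation counting, with a stated time of 1 h; a lower number here means a stronger inhibitor, a higher number a weaker inhibitor:
- compound 1 `Cc1[nH]c2ccc(Br)cc2c1C1=CCNCC1` gives 10 nM
- compound 2 `Cc1[nH]c2ccccc2c1C1=CCNCC1` gives 200 nM
- compound 3 `Cc1[nH]c2ccc(OS(=O)(=O)C(F)(F)F)cc2c1C1=CCNCC1` gives 50 nM

Compound 3 holds the second highest of the three numbers. Its nearest neighbour is compound 2, separated by a 4.0-fold lower number from compound 2 to compound 3 (0.60 log units; beyond the scatter), while the furthest is compound 1, separated by a 5.0-fold higher number from compound 1 to compound 3 (0.70 log units; beyond the scatter). The whole spread of the set is set by a 20-fold higher number from compound 1 to compound 2 (1.30 log units; beyond the scatter), a large step that turns on nothing more than the group at one aromatic carbon.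

Compound 4 `CSc1ccc2[nH]c(C)c(C3=CCNCC3)c2c1` continues this single-position series. The change is methylsulfanyl in place of ((trifluoromethyl)sulfonyl)oxy on an aromatic carbon. The methylsulfanyl group enters where bromo, hydrogen and the sulfonyloxy group have already been compared, so all three measured steps bear on it. They show that any substituent at this carbon gives a lower number than hydrogen, and that the bromo compound 1 gives the lowest number of all. The sulfonyloxy group of compound 3 sits in the middle, and a small group with one heavy-atom acceptor, as in compound 4, is expected to land between compound 3 and compound 1, closer to compound 3.

Compound 4 is therefore expected to give a modestly lower number than compound 3 in this assay, a step of a 2.0-fold lower number from compound 3 to compound 4 (0.30 log units; within the scatter), and its estimated value is 25 nM with a range of 8 nM to 80 nM.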

Compound 4, half-maximal inhibitory concentration: 20 nM
Estimate against measurement, compound 4: 1.3-fold (0.10 log units) above; low and high end bracket the measured number.
By their numbers in this assay, from the lowest: compounds 1 and 4 (each within the scatter of the next); then compound 3; then compound 2.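

In (this assay) this aromatic carbon takes methylsulfanyl, 2 heavy atoms, with no separation from bromo (a 2.0-fold higher number from compound 1 to compound 4 (0.30 log units; within the scatter)), so among the groups shown bromo no longer stands alone at the low end of the numbers. Replacing ((trifluoromethyl)sulfonyl)oxy, 8 heavy atoms and 3 hydrogen-bond acceptors, with methylsulfanyl, 1 hydrogen-bond acceptor, moves the number clearly (a 2.5-fold lower number from compound 3 to compound 4 (0.40 log units; beyond the scatter)), and against hydrogen the same group gives a step (a 10-fold lower number from compound 2 to compound 4 (1.00 log units; beyond the scatter)) that now extends the advantage over hydrogen to three different substituents, with compound 3 clearly short of the other two. No measurement at hand accounts for these differences.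

Open, on these data alone, is whether the match between methylsulfanyl and bromo holds for a longer chain such as ethylsulfanyl, or for methoxy, chloro or iodo at the same carbon. Also open, as far as these compounds go, is whether an amine or a carboxylic acid there would keep the number near those of compound 1 and compound 4 or return it towards that of the unsubstituted compound 2.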